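The compounds below may be only part of what the source reports. "The series", "measured", "known", "first", "only" and "open" are said of these compounds alone.

Working notes on the quinone series in a functional assay on SAOS-2 cells (Homo sapiens) for cytotoxicity, read by MTT assay, with a stated time of 48 h; on this read-out lower numbers stand for stronger inhibition and higher numbers for weaker inhibition.

Compound 1 `CC(C)=CC[C@H](OC(=O)C=C(C)C)C1=CC(=O)c2c(O)ccc(O)c2C1=O` gives 840 nM in this assay. Compound 2 `COc1ccc(O)c2c1C(=O)C=C([C@H](CC=C(C)C)OC(C)=O)C2=O` gives 13800 nM, the highest of the two numbers recorded; its nearest neighbour is compound 1, whose number sits well beyond the scatter below it. Among the compounds with values here, compound 1 and compound 2 differ in more than one place, so the two values show only that compound 2 is the weaker of the pair, not which change is responsible.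

Compound 3 `COc1ccc(O)c2c1C(=O)C=C([C@H](CC=C(C)C)OC(=O)C=C(C)C)C2=O` has not yet been measured. Relative to compound 2 it carries 2-methylprop-1-en-1-yl in place of methyl on a carbonyl carbon. This is the same ester that compound 1 carries, and compound 1 gives 840 nM. The expectation for compound 3 is therefore a step downward from compound 2 of moderate size, beyond the scatter, a 3.5-fold lower number from compound 2 to compound 3 (0.54 log units; beyond the scatter). The estimate for compound 3 in this assay is 4000 nM, with a range from 1000 nM to 14000 nM.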

Compound 3, half-maximal inhibitory concentration: 14500 nM
Compound 3: middle estimate off by 3.6-fold (0.56 log units), on the low side; the measured number lies above the stated range.
By their numbers in this assay, from the lowest: compound 1; then compounds 2 and 3 (each within the scatter of the next).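

In this assay the change from methyl to 2-methylprop-1-en-1-yl on a carbonyl carbon gives a 1.1-fold higher number from compound 2 to compound 3 (0.02 log units; within the scatter) and so separates the two esters by no more than the scatter when methyl sits on the oxygen on an aromatic ring. The ester shared with compound 1 therefore does not by itself bring compound 3 near the number of compound 1. Within the data shown here, with that ester held constant, methyl in place of hydrogen on an oxygen on an aromatic ring gives a 17-fold higher number from compound 1 to compound 3 (1.24 log units; beyond the scatter) in this assay, the only large step in this small set.

Open, as far as these compounds go, is whether the two esters also stay within the scatter with hydrogen on that oxygen, and what an ethyl or a longer chain there would give. No available measurement bears on what lies behind either step.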